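Allyl-substituted core series: aryl variation and cytotoxicity on Huh-7

This account rests on a few compounds, and the source may have more. Where it says the series, first, only, none or still open, it means among the compounds named here.

The series shares one core carrying an allyl group and a 2-methoxyphenyl arm, and varies the second aryl arm. Compound 1 `C=CCn1c(=O)/c(=C\c2cccc(F)c2)[nH]c(=O)/c1=C\c1ccccc1OC` carries a 3-fluorophenyl there and in a functional assay on Huh-7 cells (Homo sapiens) for cytotoxicity, read by CCK-8 assay, with a stated time of 72 h (a higher number here means a weaker inhibitor, a lower number a stronger inhibitor), compound 1 gives 27200 nM. Compound 2 `C=CCn1c(=O)/c(=C\c2cc(F)ccc2C)[nH]c(=O)/c1=C\c1ccccc1OC` carries a 5-fluoro-2-methylphenyl and in this assay compound 2 gives 5600 nM. Within the data shown here, the only measured step is a 4.9-fold lower number from compound 1 to compound 2 (0.69 log units; beyond the scatter). Compound 3 `C=CCn1c(=O)/c(=C\c2ccc(C)cc2)[nH]c(=O)/c1=C\c1ccccc1OC` carries a 4-methylphenyl; in this assay compound 3 gives "not active" (no number reported), so no number stands for it and it cannot be placed against compound 1 or compound 2 on the scale.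

Compound 4 `C=CCn1c(=O)/c(=C\c2cc(Br)ccc2F)[nH]c(=O)/c1=C\c1ccccc1OC` is not yet measured. The change from compound 3 is 5-bromo-2-fluorophenyl in place of 4-methylphenyl on a double-bonded chain carbon bound to an aromatic carbon. Among the measured compounds shown here, no measured step connects the 4-methylphenyl arm to any other arm, so the step from compound 3 to compound 4 cannot be sized from the data. What bears on compound 4 indirectly is the resemblance of the 5-bromo-2-fluorophenyl to the 5-fluoro-2-methylphenyl of compound 2, whose value in this assay is the lowest number measured, together with the step from compound 1 to compound 2. Compound 4 is therefore expected to give a number near that of compound 2, with wide uncertainty; the estimate for compound 4 in this assay is 9000 nM, within 2500 nM to 40000 nM.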

Compound 4, half-maximal inhibitory concentration: "not active" (no number reported)
Nothing numeric was reported for compound 4; there is nothing to compare the estimate with.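

In this assay compound 4 gives "not active" (no number reported) and compound 3 gives "not active" (no number reported), so no new step can be read between them. The compounds shown leave open how the 4-methylphenyl and 5-bromo-2-fluorophenyl arms would rank against compound 1 and compound 2 on the scale. Nothing shown offers an explanation for either result.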